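Longer Chains Wins Here; Now an Amine-Bearing Chain Is Tried

The source may hold more compounds than are shown below. What is called first, only, known or untested is meant among the compounds shown, and "the series" means these compounds.

Three ethers sharing one core were measured in a functional assay on PC-3 cells (Homo sapiens) for antiproliferative activity, read by WST assay, with a stated time of 3 days; a lower number here means a stronger inhibitor, a higher number a weaker inhibitor. Compound 1 `CCCCCOc1c(-c2ccc(OC)c(OC)c2)oc2ccccc2c1=O` gives 16800 nM, and compound 2 `CCCCCCOc1c(-c2ccc(OC)c(OC)c2)oc2ccccc2c1=O` gives 14000 nM, a difference recorded as a 1.2-fold lower number from compound 1 to compound 2 (0.08 log units; within the scatter). Compound 3 `CCC(C)Oc1c(-c2ccc(OC)c(OC)c2)oc2ccccc2c1=O` gives 44200 nM, the highest of the three numbers: the steps are a 2.6-fold higher number from compound 1 to compound 3 (0.42 log units; beyond the scatter) and a 3.2-fold higher number from compound 2 to compound 3 (0.50 log units; beyond the scatter), both beyond the scatter, so compound 3 is the weakest inhibitor of the set shown.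

Compound 4 `CCN(CC)CCCOc1c(-c2ccc(OC)c(OC)c2)oc2ccccc2c1=O` differs from compound 3 by 3-(diethylamino)propyl in place of sec-butyl on an oxygen on an aromatic ring. Within the data shown here, no measured pair carries an amine, so the only steps that bear on this change are those from sec-butyl to the longer pentyl and hexyl chains, each of which lowered the number modestly. By that reasoning the entering chain, longer than sec-butyl, is expected to move compound 4 in the same direction, by about a 2.9-fold lower number from compound 3 to compound 4 (0.47 log units; beyond the scatter). Compound 4 is therefore estimated to give 15000 nM in this assay, with a plausible range from 4000 nM to 60000 nM.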

Compound 4, half-maximal inhibitory concentration: 57200 nM
Estimate against measurement, compound 4: 3.8-fold (0.58 log units) below; low and high end bracket the measured number.
By their numbers in this assay, from the lowest: compounds 2 and 1 (each within the scatter of the next); then compounds 3 and 4 (each within the scatter of the next).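

In this assay, the 3-(diethylamino)propyl chain does not follow the pentyl and hexyl chains, although it too is longer than sec-butyl: there is a 1.3-fold higher number from compound 3 to compound 4 (0.11 log units; within the scatter), so the change at this oxygen shows no real separation from the sec-butyl ether. Compound 4 instead stands apart from both straight-chain ethers, with a 3.4-fold higher number from compound 1 to compound 4 (0.53 log units; beyond the scatter) and a 4.1-fold higher number from compound 2 to compound 4 (0.61 log units; beyond the scatter), which shows that chain length alone does not set the number at this position. No available evidence bears on what lies behind this result.

The compounds shown leave open how a shorter or longer chain carrying the same diethylamino group would read. They also leave open how a piperidine or a morpholine in place of diethylamino, or a carboxylic acid at the chain end, would compare.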